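Swapping an Isopropyl for Bromo on the Aryl Ring

The source may hold more compounds than are shown below. What is called first, only, known or untested is meant among the compounds shown, and "the series" means these compounds.

Compound 1, `CC(C)c1ccc(N2C(=O)C=CC2OCC(F)(F)F)cc1`, has the highest number among the two compounds measured; in a functional assay on MDA-MB-231 cells (Homo sapiens) for inhibition (on this read-out higher numbers stand for weaker inhibition and lower numbers for stronger inhibition), compound 1 gives 6640 nM. Its neighbour compound 2, `O=C1C=CC(OCC(F)(F)F)N1c1ccc(F)c(Cl)c1`, gives 3440 nM in this assay, a gap that stays within the usual scatter. Compound 3, `O=C1C=CC(OCC(F)(F)F)N1c1ccc(Br)cc1`, differs from compound 1 by bromo in place of isopropyl on an aromatic carbon. Among the compounds with values here, no measured pair shows such a change, so the step is expected to be small, a 1.5-fold lower number from compound 1 to compound 3 (0.17 log units; within the scatter), leaning slightly toward stronger inhibition because compound 2, whose ring carries fluoro and chloro groups, gives 3440 nM. Compound 3 is therefore estimated at 4500 nM, within 1500 nM to 13000 nM.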

Compound 3, half-maximal inhibitory concentration: 7570 nM
For compound 3 the middle estimate is 1.7-fold (0.23 log units) below the measured one; low and high end bracket the measured number.
By their numbers in this assay, from the lowest: compounds 2, 1 and 3 (each within the scatter of the next, the first and the last beyond it).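

In this assay, putting bromo in place of isopropyl on this aromatic carbon, para to a large group, gives a 1.1-fold higher number from compound 1 to compound 3 (0.06 log units; within the scatter), so the two compounds cannot be told apart on this read-out. At this position, then, a single bromine atom and the three carbons of isopropyl give numbers within the scatter of each other. Nothing at hand explains this result. On these data alone, whether an amine, a carboxylic acid or a longer chain on this carbon would move the number beyond the scatter remains open.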